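Swapping a Basic Side Chain for Benzyl on the Amide

The source may hold more compounds than are shown below. What is called first, only, known or untested is meant among the compounds shown, and "the series" means these compounds.

Measured compounds:
Compound 1, `COc1ccc(-c2csc(C(=O)N(C)C)n2)cc1S(=O)(=O)Nc1cccc(NCCNC(=O)c2cccc(C)c2)c1`: 73%
Compound 2, `COc1ccc(-c2cccc(C(=O)N(C)CCN(C)C)c2)cc1S(=O)(=O)Nc1cccc(NCCNC(=O)c2cccc(C)c2)c1`: 85%

Compound 2 shows the higher of the two values in a functional assay on CHO-RD-HGA16 cells for agonist activity at Orexin receptor type 2 (Homo sapiens), read by fluorescence and calcium flux, with a stated time of 30 min; on this read-out lower numbers stand for smaller maximal responses and higher numbers for larger maximal responses; compound 1 lies a distance below it that is beyond the usual scatter. Compound 3, `COc1ccc(-c2cccc(C(=O)N(C)Cc3ccccc3)c2)cc1S(=O)(=O)Nc1cccc(NCCNC(=O)c2cccc(C)c2)c1`, has not yet been measured. It differs from compound 2 in one place: phenyl in place of (dimethylamino)methyl on a saturated chain carbon bound to an amide-type nitrogen. Going by the values given here, no measured pair shows this kind of change, so nothing here tells how large its effect should be. A step within the scatter, or a small one, is expected for a number 7 percentage points lower from compound 2 to compound 3 (within the scatter). Compound 3 is estimated to give 78% in this assay, expected between 60% and 95%.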

Compound 3, largest response reached (Emax), in percent of the reference or control that the assay uses: 61%
Compound 3: middle estimate off by 17 percentage points, on the high side; measured number inside the range.
By their numbers in this assay, from the lowest: compound 3; then compound 1; then compound 2.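

In this assay, a change on the amide nitrogen gives a number 24 percentage points lower from compound 2 to compound 3 (beyond the scatter) when 2-(dimethylamino)ethyl gives way to benzyl. The maximal response therefore depends on what this side chain carries, so the two groups are not interchangeable here. Nothing available explains why the number falls. The compounds shown leave open whether losing the dimethylamino group or gaining the phenyl ring matters more, since both change in one step. A plain ethyl group or a 3-(dimethylamino)propyl chain on the same nitrogen would help separate the two.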